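Swapping the Aryl Group on the Sulfonyl Sulfur

The source may report more compounds than this note shows. Statements on the series, on what has been measured and on what is new or still open speak of the compounds shown alone.

Among the compounds with values here, compound 2 `Cc1ccc(S(=O)(=O)c2cnc3cc(F)ccc3c2-c2cccc(F)c2)cc1C` is one of only two compounds measured in an ADME assay on microsomes from liver (Homo sapiens) for metabolic stability, tested at 2.5 uM (a lower number here means slower removal, a higher number faster removal of the compound), where compound 2 gives 3.71 mL/min. Its sole companion, compound 1 `COc1cccc(S(=O)(=O)c2cnc3cc(F)ccc3c2-c2cccc(F)c2)c1`, gives 3.36 mL/min in this assay, and the step of a 1.1-fold higher number from compound 1 to compound 2 (0.04 log units; within the scatter) leaves the two values within the scatter. Compound 3 `O=S(=O)(c1ccc(F)c(Cl)c1)c1cnc2cc(F)ccc2c1-c1cccc(F)c1` carries 3-chloro-4-fluorophenyl in place of 3,4-dimethylphenyl on a sulfonyl sulfur. Within the data shown here, the single measured step, a 1.1-fold higher number from compound 1 to compound 2 (0.04 log units; within the scatter), also exchanged the group on the sulfonyl sulfur and stayed within the scatter, so for compound 3 no shift beyond the scatter is expected in this assay, a step of a 1.0-fold lower number from compound 2 to compound 3 (0.01 log units; within the scatter). Compound 3 is therefore estimated at 3.6 mL/min, in the range 1.8 mL/min to 7.2 mL/min.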

Compound 3, intrinsic clearance in a liver preparation (reported as CLH), per the amount of preparation that the assay uses: 0.25 mL/min
Compound 3: middle estimate off by 14-fold (1.16 log units), on the high side; measured number outside the range, below it.
By their numbers in this assay, from the lowest: compound 3; then compounds 1 and 2 (each within the scatter of the next).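

The aryl group on the sulfonyl sulfur, which had looked indifferent in the exchange between 3-methoxyphenyl and 3,4-dimethylphenyl, proves able to shift this assay strongly. Placing 3-chloro-4-fluorophenyl there brings a 15-fold lower number from compound 2 to compound 3 (1.17 log units; beyond the scatter), and likewise a 13-fold lower number from compound 1 to compound 3 (1.13 log units; beyond the scatter), so removal is much slower against both earlier compounds. Nothing given here bears on why this happens. The compounds shown leave open whether the step goes with the chlorine, the fluorine or both together. They also leave open how an amine or a carboxylic acid would behave on a phenyl ring at this sulfonyl sulfur.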